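A few compounds are considered here, and "the series" means these few. Any claim that something is new, unique, unknown or untested is made for them only; others in the source may bear on it.

Working notes on the series, read in a functional assay on MDA-MB-231 cells (Homo sapiens) for antiproliferative activity, read by MTT assay, with a stated time of 48 h; a higher number here means a weaker inhibitor, a lower number a stronger inhibitor. Compound 1 (`CN1C(=O)C(O)(Cc2nnn[nH]2)c2cc(F)ccc21`) gives > 100000 nM, which is a limit and not a number. Compound 2 (`O=C1N(Cc2ccc(Br)cc2)c2ccc(F)cc2C1(O)Cc1nnn[nH]1`) gives > 100000 nM, also a limit. Both compounds therefore stand at the limit of > 100000 nM in this assay, at which 2 of the 2 values shown sit, and compound 1 has no readable position beyond that.

Compound 3 (`CN1C(=O)C(O)(Cc2nnn[nH]2)c2cc(Br)ccc21`) keeps the core of compound 1 and changes one group: bromo in place of fluoro on an aromatic carbon. Among the measured compounds shown here, the one measured step, a step that the two limits leave unreadable from compound 1 to compound 2, concerns a different place on the core and gives no size to carry over. For the measured compounds named here, no step on the aromatic carbon has been measured, so no shift in either direction can be derived for this assay, and none beyond the scatter is expected. The expected step is a number no higher from compound 1 to compound 3 (the limit leaves the size open). Compound 3 is estimated at 100000 nM, within an expected range of 40000 nM to 200000 nM.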

Compound 3, half-maximal inhibitory concentration: 67300 nM
Compound 3: the middle estimate sits 1.5-fold (0.17 log units) above what was measured, within the range that was stated.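

With bromo in place of fluoro on an aromatic carbon, this assay gives an at least 1.4-fold lower number from compound 1 to compound 3 (0.17 log units; that floor lies within the scatter). Among the compounds shown here, this is the first step with a floor on its size, although the true size remains open and the floor alone does not set this change apart from the scatter. Compound 3 is also the only compound shown that stands apart from the limit shared by the others: the limit of > 100000 nM in this assay, at which 2 of the 3 values shown sit.

From the compounds shown here alone, the step with 4-bromophenyl on the chain carbon bound to the amide-type nitrogen cannot be read, so whether that change would act alongside bromo on the aromatic carbon remains open. Also open, going by these compounds, is whether chloro, methoxy or an amine on that aromatic carbon would give a number clearly beyond the scatter from that of compound 3.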